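Nucleoside series: cytotoxicity on a human liver cell line

A few compounds are considered here, and "the series" means these few. Any claim that something is new, unique, unknown or untested is made for them only; others in the source may bear on it.

Compound 1 `OC[C@H]1O[C@@H](n2cnc3c(COc4ccccc4)ncnc32)[C@H](O)[C@@H]1O`: > 100000 nM
Compound 2 `CN(Cc1ncnc2c1ncn2[C@@H]1O[C@H](CO)[C@@H](O)[C@H]1O)c1ccccc1`: 21000 nM

Going by the values given here, in a functional assay on Huh-7 cells (Homo sapiens) for cytotoxicity, read by MTT assay, with a stated time of 3 days (on this read-out lower numbers stand for higher toxicity in this test and higher numbers for lower toxicity in this test), compound 2 gives 21000 nM and is the only compound with a number. For compound 1 the read-out is a limit, > 100000 nM. Compound 1 sits at the limit of > 100000 nM in this assay, at which 1 of the 2 values shown sits. Compound 3 `OC[C@H]1O[C@@H](n2cnc3c(CN4CCCCC4)ncnc32)[C@H](O)[C@@H]1O` differs from compound 2 by piperidin-1-yl in place of methyl(phenyl)amino on a saturated chain carbon bound to an aromatic carbon. Among the compounds with values here, the one measured step, an at least 4.7-fold lower number from compound 1 to compound 2 (0.67 log units; beyond the scatter), changed the group at the same place and lay beyond the scatter, but piperidin-1-yl does not occur in it, so no step bears directly on the change. The step is estimated as a 1.9-fold higher number from compound 2 to compound 3 (0.28 log units; within the scatter), with no clear direction. Compound 3 is expected at 40000 nM, within 12000 nM to 150000 nM.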

Compound 3, half-maximal cytotoxic concentration: 87000 nM
Compound 3: middle estimate off by 2.2-fold (0.34 log units), on the low side; measured number inside the range.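

In this assay piperidin-1-yl in place of methyl(phenyl)amino on a saturated chain carbon bound to an aromatic carbon gives a 4.1-fold higher number from compound 2 to compound 3 (0.62 log units; beyond the scatter) (a modest step), so the read-out at this place depends on which amine is present and not on an amine nitrogen alone. Compound 2 is the most toxic of the three in this test. Piperidin-1-yl in place of phenoxy gives an at least 1.1-fold lower number from compound 1 to compound 3 (0.06 log units; that floor lies within the scatter) and this floor cannot be read as a change. Compound 1 stands at a limit: the limit of > 100000 nM in this assay, at which 1 of the 3 values shown sits.

On these data alone, what a dimethylamino or a morpholin-4-yl group would give at this place stays open. So does whether the aromatic ring of methyl(phenyl)amino goes with the higher toxicity of compound 2.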